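This account rests on a few compounds, and the source may have more. Where it says the series, first, only, none or still open, it means among the compounds named here.

Working notes on the series. All three measured compounds share the core of compound 1 `COc1cc(/C=C/C=C/C(=O)N2CCCCC2)cc(OC)c1OC` and differ in their substitution. In an assay for inhibition of Polyunsaturated fatty acid 5-lipoxygenase (Homo sapiens), read by spectrophotometry, tested at 20 uM (a lower number here means less inhibition, a higher number more inhibition at the concentration tested (going by the name of the read-out)), compound 1 gives 66.7%. Compound 3 `O=C(/C=C/C=C/c1ccc(O)c(O)c1)N1CCCCC1` gives 82.8% in this assay. Compound 2 `CN(C)c1ccc(/C=C/C=C/C(=O)N2CCCCC2)cc1` gives 13.4%, the lowest of the three numbers; compound 1 lies nearest to it and compound 3 furthest, both beyond the scatter. Compound 4 `CC(=O)Oc1ccc(/C=C/C=C/C(=O)N2CCCCC2)cc1` is not yet measured in this assay. It differs from compound 2 by acetoxy in place of dimethylamino on an aromatic carbon. Among the measured compounds shown here, no step between measured compounds covers this change, so the expectation rests only on the spread of the three numbers. Because compound 2 sits at 13.4% while compound 1 and compound 3 sit higher, a moderate rise in inhibition is expected. The expected step from compound 2 to compound 4 is a number 21.6 percentage points higher from compound 2 to compound 4 (beyond the scatter). Compound 4 is estimated at 35%, within 10% to 65%.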

Compound 4, a percentage reported as inhibition, at one concentration (the size of the read-out at that concentration, not a potency): 18.3%
Compound 4: middle estimate off by 16.7 percentage points, on the high side, within the range that was stated.
By their numbers in this assay, from the lowest: compounds 2 and 4 (each within the scatter of the next); then compound 1; then compound 3.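

In this assay, among the compounds shown here, acetoxy in place of dimethylamino on an aromatic carbon, para to a large group, gives a number 4.9 percentage points higher from compound 2 to compound 4 (within the scatter) and is the first single-place step. At this position, the two groups cannot be told apart by this read-out, even though they differ in their atoms. No measurement at hand explains why they read alike. On these data alone, whether a hydroxyl, a primary amine or a carboxylic acid on this aromatic carbon would read apart from these two groups stays open.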